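The source may report more compounds than this note shows. Statements on the series, on what has been measured and on what is new or still open speak of the compounds shown alone.

Measured compounds:
Compound 1, `CSCC[C@H](NC(=O)CN(c1ncnc2c1ncn2C1CCCCO1)C1CC1)C(=O)OCc1ccccc1`, 17.5%
Compound 2, `O=C(CN(c1ncnc2c1ncn2C1CCCCO1)C1CC1)NCC(=O)OCc1ccccc1`, 7.26%
Compound 3, `O=C(CN(c1ncnc2c1ncn2C1CCCCO1)C1CC1)N[C@@H](CC(=O)OCc1ccccc1)C(=O)OCc1ccccc1`, 0.06%

In a functional assay on the whole organism (Tail, strain ICR) with Mus musculus as the target, in the tail flick test, with a stated time of 150 min, at a dose of 25 umol/kg by the oral route (a higher number here means a stronger effect of the compound at the dose given, a lower number a weaker effect), compound 3 stands lowest of the three numbers; compound 2 lies nearest to it, and the gap between them is within the scatter, while compound 1 lies furthest, beyond the scatter. Compound 4 is `C[C@@H](O)[C@H](NC(=O)CN(c1ncnc2c1ncn2C1CCCCO1)C1CC1)C(=O)OCc1ccccc1`; it differs from compound 3 as follows: 1-hydroxyethyl in place of (benzyloxycarbonyl)methyl on a saturated chain carbon bound to an amide-type nitrogen and a carbonyl carbon.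

Among the measured compounds shown here, two measured steps bear on this change. The step of a number 7.2 percentage points lower from compound 2 to compound 3 (within the scatter) shows that adding the (benzyloxycarbonyl)methyl group to the bare chain carbon did not move this assay beyond the scatter. The step of a number 10.2 percentage points lower from compound 1 to compound 2 (beyond the scatter) shows that removing a small side chain cost a modest amount. Compound 4 carries a small side chain again, so a modest rise from compound 3 is expected, though a step within the scatter is equally plausible. The expected step is a number 7.9 percentage points higher from compound 3 to compound 4 (within the scatter). Compound 4 is therefore estimated at 8%, within a range from 0% to 20%.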

Compound 4, a percentage reported as activity, at one dose (the size of the read-out at that dose, not a potency): 6.53%
Estimate against measurement, compound 4: 1.5 percentage points above; the range from low to high includes it.
By their numbers in this assay, from the lowest: compounds 3, 4 and 2 (each within the scatter of the next); then compound 1.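

In this assay, the step of a number 6.5 percentage points higher from compound 3 to compound 4 (within the scatter) shows that 1-hydroxyethyl and the much larger (benzyloxycarbonyl)methyl, with its aromatic ring, are not told apart at this saturated chain carbon, and the step of a number 0.7 percentage points lower from compound 2 to compound 4 (within the scatter) shows the same for 1-hydroxyethyl and hydrogen. Only 2-(methylsulfanyl)ethyl stands apart, with the step of a number 11 percentage points lower from compound 1 to compound 4 (beyond the scatter), so among these four compounds a small side chain as such does not bring back the higher number. No evidence is available on why 2-(methylsulfanyl)ethyl differs here.

On these data alone, it remains open whether the sulfur atom or the chain length matters, which a plain butyl chain or a longer thioether at this place would address. An amine or a carboxylic acid at this carbon also remains untested among the compounds shown.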